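Propyl in Place of Tert-Butoxy on a Shared Core

This account rests on a few compounds, and the source may have more. Where it says the series, first, only, none or still open, it means among the compounds named here.

Measured in an assay on membranes from HeLa cells for displacement of a labelled ligand from adenosine receptor A3 (Homo sapiens), read by scintillation counting, with a stated time of 180 min, tested at 1 uM; a higher number here means more inhibition at the concentration tested (going by the name of the read-out), a lower number less inhibition:
Compound 1 `CC1=C(C(=O)OC(C)(C)C)C(c2ccsc2)NC(=O)N1`: 1%
Compound 2 `CC1=C(C(=O)OC(C)(C)C)C(c2ccsc2)NC(=O)N1C`: 14%

Compound 1 gives the lowest of the two numbers, and compound 2 sits higher by a number 13 percentage points higher from compound 1 to compound 2 (beyond the scatter). Compound 3 `CCCC(=O)C1=C(C)NC(=O)NC1c1ccsc1` differs from compound 1 in one place: propyl in place of tert-butoxy on a carbonyl carbon. For the measured compounds named here, the only measured step, methyl in place of hydrogen on an amide-type nitrogen in a ring, touches a different part of the shared core, so no measured step bears on this change. Nothing beyond the scatter is therefore expected in this assay. The expected step is a number 4 percentage points higher from compound 1 to compound 3 (within the scatter). Compound 3 is estimated to give 5%, within a range from 0% to 25%.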

Compound 3, a percentage reported as inhibition, at one concentration (the size of the read-out at that concentration, not a potency): 1%
Estimate against measurement, compound 3: 4 percentage points above; measured number inside the range.
By their numbers in this assay, from the lowest: compounds 1 and 3 (each within the scatter of the next); then compound 2.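

In this assay, the change at this carbonyl carbon gives no change at the digits printed from compound 1 to compound 3 (within the scatter). For the compounds shown here, this is the first reading at this position, and it shows that replacing tert-butoxy with propyl, which removes the oxygen attached there, does not raise the number. Compound 1 already gives 1%, so this low starting value leaves almost no room to see any loss.

From the compounds shown here alone, whether an amine or a longer chain in place of propyl would raise the number remains open. Nothing available explains this result.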